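The source may report more compounds than this note shows. Statements on the series, on what has been measured and on what is new or still open speak of the compounds shown alone.

Compound 1 `CN(C)C(=O)c1ccc(S(=O)(=O)c2ccc(NC(=O)[C@@](C)(O)C(F)(F)F)c(Cl)c2)cc1`: in an ADME assay for inhibition of Bile salt export pump (Homo sapiens), read by scintillation counting, with a stated time of 5 min (on this read-out lower numbers stand for stronger inhibition and higher numbers for weaker inhibition), compound 1 gives only a limit, < 12900 nM.
Compound 2 `O=C(O)c1cc2c(F)c(O)ccc2n1Cc1ccc(Cl)c(Cl)c1`: in this assay compound 2 gives 19300 nM.
Compound 3 `O=C(c1ccc(-c2ccncc2)cc1)N1CCN(S(=O)(=O)c2cc3cc(Cl)ccc3[nH]2)CC1`: in this assay compound 3 gives only a limit, < 10000 nM.

Compound 2 therefore holds the only real number in this assay among these three; the other two results are limits of the assay rather than numbers. One of them is the limit of < 12900 nM in this assay, at which 1 of the 3 values shown sits. The other is the limit of < 10000 nM in this assay, at which 1 of the 3 values shown sits.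

Compound 4 `O=C(O)c1cc2cc(O)ccc2n1Cc1ccc(Cl)c(Cl)c1` differs from compound 2 by hydrogen in place of fluoro on an aromatic carbon. Within the data shown here, no measured pair among the three compounds shows such a change, so there is no observed step to lean on. For a change this small, no step beyond the usual scatter is expected in this assay, with at most a slight drift toward weaker inhibition. Compound 4 is thus estimated to give 23000 nM in this assay, within a range from 9000 nM to 55000 nM. That estimate means an expected step of a 1.2-fold higher number from compound 2 to compound 4 (0.08 log units; within the scatter), inside the scatter.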

Compound 4, half-maximal inhibitory concentration: 49800 nM
Estimate against measurement, compound 4: 2.2-fold (0.34 log units) below; the range from low to high includes it.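

Hydrogen in place of fluoro on this aromatic carbon, ortho to a hydroxy group and ortho to a fused ring, gives in this assay a step of a 2.6-fold higher number from compound 2 to compound 4 (0.41 log units; beyond the scatter) toward weaker inhibition. Among these compounds, the earlier compounds offered no pair differing in one place, so this is the first sign that the position responds to so small a change. Nothing among the results shown bears on why.

The compounds shown leave open whether a methoxy group or an amine at this position would shift the number further. They also leave open whether the same exchange would give a similar step on another core.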